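Swapping methoxy for fluoro on the aryl ring

The source may report more compounds than this note shows. Statements on the series, on what has been measured and on what is new or still open speak of the compounds shown alone.

Of the compounds shown here, three sharing one core have been measured in a functional assay on CCRF-CEM cells (Homo sapiens) for cytotoxicity, with a stated time of 72 h; a higher number here means a weaker inhibitor, a lower number a stronger inhibitor. Compound 1 `CN(C)c1ccc(/C=C2\CCC/C(=C\c3ccccc3[N+](=O)[O-])C2=O)cc1` gives 168000 nM. Compound 2 `Cc1ccc(/C=C2\CCC/C(=C\c3ccccc3[N+](=O)[O-])C2=O)cc1` gives 6090 nM, and compound 3 `COc1ccc(/C=C2\CCC/C(=C\c3ccccc3[N+](=O)[O-])C2=O)cc1` gives 7450 nM. Compound 3 thus has the second highest number of the three: it sits close to compound 2, the pair differing only by a 1.2-fold higher number from compound 2 to compound 3 (0.09 log units; within the scatter), while compound 1 lies far away, a gap shown by a 23-fold lower number from compound 1 to compound 3 (1.35 log units; beyond the scatter). The parallel comparison a 28-fold lower number from compound 1 to compound 2 (1.44 log units; beyond the scatter) tells the same story from the other side.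

Compound 4 `O=C1/C(=C/c2ccc(F)cc2)CCC/C1=C\c1ccccc1[N+](=O)[O-]` has not yet been measured in this assay. It differs from compound 3 in one place: fluoro in place of methoxy on an aromatic carbon. Among the compounds with values here, the only step that bears directly on this spot among small groups is a 1.2-fold higher number from compound 2 to compound 3 (0.09 log units; within the scatter), which stayed within the scatter; the large steps from compound 1 involved dimethylamino, which is not present here. Fluoro, like methyl and methoxy, is a small group on that ring position, so the expected step of a 1.1-fold lower number from compound 3 to compound 4 (0.03 log units; within the scatter) is none beyond the scatter. Compound 4 is therefore estimated at 7000 nM, with a range from 3000 nM to 18000 nM.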

Compound 4, half-maximal inhibitory concentration: 1510 nM
Estimate against measurement, compound 4: 4.6-fold (0.67 log units) above; the measured number lies below the stated range.
By their numbers in this assay, from the lowest: compound 4; then compounds 2 and 3 (each within the scatter of the next); then compound 1.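

Compounds 2 and 3 alone made this position on the aromatic ring, para to a large group, look indifferent to which small group it carries, since methyl and methoxy could not be told apart in this assay. Fluoro breaks that picture, with a 4.9-fold lower number from compound 3 to compound 4 (0.69 log units; beyond the scatter) and a 4.0-fold lower number from compound 2 to compound 4 (0.61 log units; beyond the scatter), so the position does distinguish between groups of similar size, and the change from 4-methoxyphenyl to 4-fluorophenyl matters even though it removes only a little of the molecule. It also stretches the span of the series, since a 110-fold lower number from compound 1 to compound 4 (2.05 log units; beyond the scatter) makes compound 4 the strongest inhibitor of the four, with its steps to all the others beyond the scatter.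

No measurement given here explains why fluoro stands apart from methyl and methoxy. On these data alone, whether this gain belongs to fluoro alone remains open, as chloro, bromo or a nitrile at the same position would show, and so does whether it would survive a change to the nitro group on the other aromatic ring, which all four compounds share.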